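Notes on the series around compound 3

A few compounds are considered here, and "the series" means these few. Any claim that something is new, unique, unknown or untested is made for them only; others in the source may bear on it.

The series shares one core. Compound 1 `Cc1ccc(S(=O)(=O)n2cnc3c(Cl)ncnc32)cc1` carries chloro on an aromatic carbon of that core, compound 2 `Cc1ccc(S(=O)(=O)n2cnc3c(N4CCC(C)CC4)ncnc32)cc1` carries 4-methylpiperidin-1-yl there, and compound 3 `Cc1ccc(S(=O)(=O)n2cnc3c(NCc4ccc(Cl)cc4Cl)ncnc32)cc1` carries a 2,4-dichlorobenzyl amine. In a functional assay on HCT-116 cells (Homo sapiens) for cytotoxicity, read by sulforhodamine B assay, with a stated time of 72 h (on this read-out higher numbers stand for weaker inhibition and lower numbers for stronger inhibition), compound 1 gives 22800 nM, compound 2 gives 14600 nM and compound 3 gives 28100 nM. Compound 3 has the highest of the three numbers, but its gaps to compound 1 and to compound 2 are both within the scatter, so no order among the three can be read. For the measured compounds named here, the only step between single-change neighbours, a 1.6-fold lower number from compound 1 to compound 2 (0.19 log units; within the scatter), is likewise within the scatter.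

Compound 4 `Cc1ccc(S(=O)(=O)n2cnc3c(NCCC4C=CCCC4)ncnc32)cc1` differs from compound 3 by (cyclohex-2-en-1-yl)methyl in place of 2,4-dichlorophenyl on a saturated chain carbon bound to a nitrogen on an aromatic ring. Going by the values given here, no measured step touches this position: the change from compound 1 to compound 2 sits on the aromatic carbon, not on the chain carbon bound to the ring nitrogen, and compound 3 has no single-change neighbour among the measured compounds. Among the compounds with values here, all numbers so far in this assay lie in a narrow band, and nothing in the data distinguishes a 2,4-dichlorophenyl group from a (cyclohex-2-en-1-yl)methyl group at this place. The expectation is therefore no step beyond the scatter, a 1.1-fold lower number from compound 3 to compound 4 (0.05 log units; within the scatter), with wide uncertainty. Compound 4 is estimated at 25000 nM, in a range of 8000 nM to 80000 nM.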

Compound 4, half-maximal inhibitory concentration: 8700 nM
Compound 4: middle estimate off by 2.9-fold (0.46 log units), on the high side; the measured number falls inside the stated range.
By their numbers in this assay, from the lowest: compounds 4, 2, 1 and 3 (each within the scatter of the next, the first and the last beyond it).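

In this assay, for the compounds shown here, a 3.2-fold lower number from compound 3 to compound 4 (0.51 log units; beyond the scatter) is the first step beyond the scatter at this place, on a saturated chain carbon bound to a nitrogen on an aromatic ring, and it shows that the numbers respond to the group carried there, although the step is modest. Measured against the chloro group on the aromatic carbon, a 2.6-fold lower number from compound 1 to compound 4 (0.42 log units; beyond the scatter) is also beyond the scatter, while a 1.7-fold lower number from compound 2 to compound 4 (0.22 log units; within the scatter) stays within it, so (2-(cyclohex-2-en-1-yl)ethyl)amino and 4-methylpiperidin-1-yl cannot be told apart on this read-out. Nothing available bears on what lies behind the step from the 2,4-dichlorobenzyl group to the 2-(cyclohex-2-en-1-yl)ethyl group.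

This single change alters the chlorine atoms, the aromatic ring, the ring double bond and the chain length together, so the compounds shown do not assign the step to any one of them. A plain benzyl amine, a 2-(2,4-dichlorophenyl)ethyl amine and a 2-cyclohexylethyl amine at this place would pull these features apart.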